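This account rests on a few compounds, and the source may have more. Where it says the series, first, only, none or still open, it means among the compounds named here.

Measured in a functional assay on ECa-109 cells (Homo sapiens) for cytotoxicity, read by MTT assay, with a stated time of 48 h; on this read-out lower numbers stand for stronger inhibition and higher numbers for weaker inhibition:
- compound 1 `COc1ccc(-c2c[nH]c(=O)n2-c2cc(OC)c(OC)c(OC)c2)cc1`: > 50000 nM
- compound 2 `COc1ccc(-c2c[nH]c(=O)n2-c2cc(OC)c(OC)c(OC)c2)cc1N`: > 50000 nM
- compound 3 `COc1cc(-n2c(-c3ccccc3)cn(C(C)=O)c2=O)cc(OC)c1OC`: > 50000 nM

Compound 3 stands at > 50000 nM, which is a limit of the assay and not a number. The entries for compound 1 and compound 2 are limits of the same kind, so no measured number is available yet.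

Compound 4 `COc1cc(-n2c(-c3ccc(Cl)cc3)cn(C(C)=O)c2=O)cc(OC)c1OC` differs from compound 3 in one place: chloro in place of hydrogen on an aromatic carbon. Put simply, phenyl becomes 4-chlorophenyl.

Going by the values given here, the only measured step between close relatives here, a step that the two limits leave unreadable from compound 1 to compound 2, puts amino rather than chloro on an aromatic carbon, and its size cannot be read. It therefore gives no guide to the size of this change. What the compounds do offer is the limit of > 50000 nM in this assay, at which 3 of the 3 values shown sit, so no step beyond the scatter is expected in this assay, and a further limit is the likeliest report. The expected step is a number no higher from compound 3 to compound 4 (the limit leaves the size open). The estimated value for compound 4 is 50000 nM. The expected range runs from 20000 nM to 100000 nM.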

Compound 4, half-maximal inhibitory concentration: > 50000 nM
Compound 4 was reported as a limit; the forecaster's own chance of this, stated with the estimate: 75%; the middle value lies on the limit itself.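

Going by these compounds alone, compound 3 and compound 4 are both reported as limits of the assay and not as numbers, so no step between them can be read, and the same holds for the other pair: the limit of > 50000 nM in this assay, at which 4 of the 4 values shown sit. The compounds shown leave open whether chloro in place of hydrogen changes cytotoxicity at all.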